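Cinnamoyl and dienoyl threonine alkylamides against SiHa cells

The source may report more compounds than this note shows. Statements on the series, on what has been measured and on what is new or still open speak of the compounds shown alone.

Measured so far in a functional assay on SiHa cells (Homo sapiens) for cytotoxicity, read by MTT assay, with a stated time of 48 h; on this read-out higher numbers stand for weaker inhibition and lower numbers for stronger inhibition:
compound 1 `CCCCCCCCNC(=O)[C@@H](NC(=O)/C=C/c1ccccc1)[C@@H](C)O` gives 41400 nM
compound 2 `C/C=C/C=C/C(=O)N[C@H](C(=O)NCCCCCCCC)[C@@H](C)O` gives 123000 nM
compound 3 `CCCCCCCCCCCCCCNC(=O)[C@@H](NC(=O)/C=C/c1ccccc1)[C@@H](C)O` gives 35800 nM

Compound 1 and compound 3 share a core that differs in one place: hexyl in place of hydrogen on a saturated chain carbon, eight bonds along the chain from an amide-type nitrogen. This change left the read-out in this assay essentially unchanged, a 1.2-fold lower number from compound 1 to compound 3 (0.06 log units; within the scatter). Compound 3 shows the lowest number of the three, but its gap to compound 1 is within the scatter, so no order between compound 1 and compound 3 can be claimed; only compound 2 stands apart from both beyond the scatter.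

The change from compound 1 to compound 2 is described as prop-1-en-1-yl in place of phenyl on a double-bonded chain carbon bound to a double-bonded chain carbon. In this assay it produced a modest weakening, a 3.0-fold higher number from compound 1 to compound 2 (0.47 log units; beyond the scatter).

Compound 4 `C/C=C/C=C/C(=O)N[C@H](C(=O)NCCCCCCCCCCCCCC)[C@@H](C)O` is not yet measured. It differs from compound 3 by prop-1-en-1-yl in place of phenyl on a double-bonded chain carbon bound to a double-bonded chain carbon. The "place" description is the same word for word as in the step from compound 1 to compound 2, so this is the same change made on a core that carries the longer chain. Since the core change from compound 1 to compound 3 made no difference beyond the scatter, the step from compound 3 to compound 4 is expected to resemble the step from compound 1 to compound 2, that is a 3.0-fold higher number from compound 3 to compound 4 (0.48 log units; beyond the scatter) in this assay, because compound 2 sits at 123000 nM next to compound 1. Compound 4 is therefore estimated at 107000 nM in this assay, with an expected range from 50000 nM to 250000 nM.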

Compound 4, half-maximal inhibitory concentration: > 200000 nM
Compound 4 ended at the assay's limit; the forecaster's own chance of this, stated with the estimate: 10%; middle value at least 1.8-fold (0.27 log units) away from the limit.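

In this assay compound 4 gives > 200000 nM, which is a limit of the assay and not a number. Replacing phenyl with prop-1-en-1-yl on the core that carries the longer chain gives an at least 5.5-fold higher number from compound 3 to compound 4 (0.74 log units; beyond the scatter), so the weakening seen on the core of compound 1 recurs in the same direction, but whether its size is the same or larger on this second core is not shown: the same change on two cores in this assay, a 3.0-fold higher number (0.47 log units; beyond the scatter) from compound 1 to compound 2 and an at least 5.5-fold higher number (0.74 log units; beyond the scatter) from compound 3 to compound 4; the limit leaves it open whether they differ Seen from the other side, adding hexyl to the prop-1-en-1-yl compound gives an at least 1.6-fold higher number from compound 2 to compound 4 (0.21 log units; that floor lies within the scatter), so this pair shows neither that the chain extension is as silent here as it is with phenyl nor that it has an effect here: the same change on two cores in this assay, a 1.2-fold lower number (0.06 log units; within the scatter) from compound 1 to compound 3 and an at least 1.6-fold higher number (0.21 log units; that floor lies within the scatter) from compound 2 to compound 4; the limit leaves it open whether they differ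

As far as these compounds go, the carry-over rests on just two cores and one pair of groups, and the position of compound 4 past its limit stays unknown, so the steps that depend on it can be read only as floors. Open too, from the compounds shown here alone, is whether the same pattern holds with a shorter chain or a longer chain on the amide nitrogen, with an amine or a carboxylic acid in place of the hexyl, or with a chlorine-bearing phenyl in place of the phenyl.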